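Removing an Amino Group From a Soluble Core

This account rests on a few compounds, and the source may have more. Where it says the series, first, only, none or still open, it means among the compounds named here.

In a physicochemical assay for solubility, read by HPLC, in phosphate buffer, measured as kinetic solubility, with a stated time of 24 h, at 20 degrees C, at pH 7.4, tested at 100 uM (a higher number here means a more soluble compound, a lower number a less soluble compound), three compounds that share one core have been measured. Compound 1 `CC(C)n1nc(-c2ccc3oc(N)nc3c2)c2c(C#N)nc(N)nc21` gives < 1000 nM, which is a limit of the assay rather than a number. Compound 1 thus sits at the limit of < 1000 nM in this assay, at which 1 of the 3 values shown sits, and contributes no number for comparison. Compound 2 `CCCCn1nc(-c2ccc3oc(N)nc3c2)c2c(C)nc(N)nc21` gives 5200 nM. Compound 3 `CC(C)n1nc(-c2ccc3oc(N)nc3c2)c2c(=O)[nH]c(N)nc21` gives 9200 nM, the higher of the two numbers, but its gap to compound 2 lies within the usual scatter, so the two cannot be ranked against each other.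

Compound 4 `CC(C)n1nc(-c2ccc3oc(N)nc3c2)c2c(=O)[nH]cnc21` has not yet been measured. It differs from compound 3 in one place: hydrogen in place of amino on an aromatic carbon. Among the compounds with values here, no pair of measured compounds shows this particular change, so the expected effect in this assay rests on the structural change alone. The expectation is a small decrease in solubility, of a size that may not exceed the scatter. For compound 4 the estimated value in this assay is 5000 nM, with a likely range from 1500 nM to 15000 nM. The expected step is a 1.8-fold lower number from compound 3 to compound 4 (0.26 log units; within the scatter).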

Compound 4, solubility: 3000 nM
The estimate for compound 4 lay 1.7-fold (0.22 log units) above the measured number, and the stated range covers the measured number.
By their numbers in this assay, from the lowest: compounds 4, 2 and 3 (each within the scatter of the next, the first and the last beyond it). At a limit, below all of these: compound 1.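

Within the data shown here, compound 3 and compound 4 form the first measured pair that differs in only one place, so a single change on the shared core can now be read directly. In this assay, hydrogen in place of amino on the aromatic carbon between two ring nitrogen atoms gives a 3.1-fold lower number from compound 3 to compound 4 (0.49 log units; beyond the scatter), a modest step, which shows that the group at this position matters for this read-out, at least in this pair. Only compound 1 stands at a limit, which is not a number, so this step is read between two true numbers: the limit of < 1000 nM in this assay, at which 1 of the 4 values shown sits.

As far as these compounds go, whether a methylamino group, a methyl group or a fluorine atom on the same carbon would give a similar number remains open. Also open, from the compounds shown here alone, is whether the same change would give a step of this size on the core of compound 2.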